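Replacing a Saturated Ring with an Aromatic One

The source may hold more compounds than are shown below. What is called first, only, known or untested is meant among the compounds shown, and "the series" means these compounds.

Compound 3 `Cc1cccc2sc(NC(=O)CCN3CCN(C4CCCCC4)CC3)nc12` is the starting point. Going by the values given here, in an assay on membranes from liver for displacement of a labelled ligand from Sigma intracellular receptor 2 (Rattus norvegicus), read by scintillation counting, with a stated time of 120 min (on this read-out lower numbers stand for stronger inhibition and higher numbers for weaker inhibition), compound 3 gives 233 nM, the lowest of the three numbers measured so far. Compound 1 `CCCCN1CCN(CCC(=O)Nc2nc3c(C)cccc3s2)CC1` gives 1200 nM in this assay, and compound 2 `Cc1cccc2sc(NC(=O)CCN3CCN(CC4CCCO4)CC3)nc12` gives 5000 nM in this assay. The steps that lead to compound 3 are a 5.2-fold lower number from compound 1 to compound 3 (0.71 log units; beyond the scatter) and a 21-fold lower number from compound 2 to compound 3 (1.33 log units; beyond the scatter), both changes on the same amine nitrogen in a ring, and they show that cyclohexyl gave lower numbers than either of the two chains. Compound 4 `Cc1cccc2sc(NC(=O)CCN3CCN(c4ncccn4)CC3)nc12` differs from compound 3 in one place: pyrimidin-2-yl in place of cyclohexyl on an amine nitrogen in a ring. Among the compounds with values here, no measured step exchanges a saturated ring at that position for an aromatic one, so there is no direct precedent. The nearest hint is a 4.2-fold higher number from compound 1 to compound 2 (0.62 log units; beyond the scatter), where oxolan-2-yl in place of propyl gave a higher number. A modest rise in this assay is therefore expected, a 3.4-fold higher number from compound 3 to compound 4 (0.54 log units; beyond the scatter). Compound 4 is expected to give about 800 nM, within a range from 200 nM to 3000 nM.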

Compound 4, inhibition constant: > 1000 nM
Compound 4: a limit, no number (the forecaster's own chance of this, stated with the estimate: 5%); middle value at least 1.2-fold (0.09 log units) away from the limit.
By their numbers in this assay, from the lowest: compound 3; then compound 1; then compound 2.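

Compound 4 gives > 1000 nM in this assay, which is a limit of the assay and not a number. Even so, pyrimidin-2-yl in place of cyclohexyl gives an at least 4.2-fold higher number from compound 3 to compound 4 (0.63 log units; beyond the scatter), the first measured exchange of a saturated ring for an aromatic one at this position, and as the two groups have the same count of heavy atoms, that count alone does not keep the number low. The steps from compound 1 and compound 2 to compound 4 cannot be read, so compound 4 cannot be placed against those two.

The compounds shown leave open whether the rise goes with the aromatic ring or with its ring nitrogens, and phenyl, an aromatic ring of carbon only, would separate the two. From the compounds shown here alone, the actual number for compound 4 also remains unknown.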